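The source may hold more compounds than are shown below. What is called first, only, known or untested is meant among the compounds shown, and "the series" means these compounds.

Measured compounds:
- compound 1, `CCCCNC(=O)c1c(N)sc(-c2ccc(Cl)cc2)c1-c1ccc(Cl)cc1`: 8170 nM
- compound 2, `CCN(CC)CCNC(=O)Nc1sc(-c2ccc(Cl)cc2)c(-c2ccc(Cl)cc2)c1C(=O)NC1CC1`: "not determined" (no result reported)

Going by the values given here, in a functional assay on A549 cells (Homo sapiens) for inhibition, read by sulforhodamine B assay, with a stated time of 72 h (a lower number here means a stronger inhibitor, a higher number a weaker inhibitor), compound 1 gives 8170 nM, the only number available here, so it is the sole point of reference; compound 2 carries no number for comparison. Compound 3, `Nc1sc(-c2ccc(Cl)cc2)c(-c2ccc(Cl)cc2)c1C(=O)NC1CCCC1`, shares the core of compound 1 and differs from it in one place: cyclopentyl in place of butyl on an amide-type nitrogen. Among the compounds with values here, no pair of measured compounds shows how such a change moves the result, so there is nothing to calibrate against. A swap of one short carbon group for another of nearly the same size, with no donors or acceptors changing, is expected to leave the result close to where compound 1 stands. Compound 3 is therefore expected to give about 6500 nM in this assay, within a range from 2500 nM to 17000 nM, a step of a 1.3-fold lower number from compound 1 to compound 3 (0.10 log units; within the scatter) that is expected to stay inside the usual scatter.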

Compound 3, half-maximal inhibitory concentration: 6790 nM
For compound 3 the middle estimate is 1.0-fold (0.02 log units) below the measured one; the measured number falls inside the stated range.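

In this assay, going by these compounds alone, cyclopentyl in place of butyl on an amide-type nitrogen comes with a 1.2-fold lower number from compound 1 to compound 3 (0.08 log units; within the scatter), and this is the first pair of compounds that differ in one place. It shows that at this position an open butyl chain and a five-membered carbon ring, which has one more carbon, cannot be told apart in this measurement. No measured property in the available data bears on this result.

A single swap between two groups made only of carbon cannot show how much this position matters overall. From the compounds shown here alone, whether a longer chain, a cyclohexyl ring or a chain ending in an amine on this nitrogen would move the number beyond the usual scatter remains open.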